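One Added Methyl on a Two-Compound Scale

A few compounds are considered here, and "the series" means these few. Any claim that something is new, unique, unknown or untested is made for them only; others in the source may bear on it.

Among the measured compounds shown here, only two compounds have numbers so far in a functional assay on MCF7 cells (Homo sapiens) for inhibition, in the presence of a further agent that is not named here (a lower number here means a stronger inhibitor, a higher number a weaker inhibitor), and the comparison is short. Compound 1 (`Cc1ccc(N)c2c(=O)cc(-c3ccc(N)c(F)c3)oc12`) gives 180 nM as the lower of the two numbers, while compound 2 (`Nc1ccc(-c2cc(=O)c3c(N)c(Cl)cc(Cl)c3o2)cc1`) gives 610 nM and the gap between them lies beyond the usual scatter. That makes compound 1 the stronger inhibitor of this pair. Compound 3 (`Cc1cc(C)c2oc(-c3ccc(N)c(F)c3)cc(=O)c2c1N`) has not been measured and differs from compound 1 in one place: methyl in place of hydrogen on an aromatic carbon describes the change. A methyl takes the place of a hydrogen on an aromatic carbon, ortho to an amino group and meta to a methyl group. For the measured compounds named here, no two measured compounds differ in just one place, so the data show no direct precedent for this step. A modest weakening is expected, drifting towards compound 2 at 610 nM as a loose reference, though a change within the scatter would be no surprise. In numbers, the expected step is a 1.7-fold higher number from compound 1 to compound 3 (0.22 log units; within the scatter) and it remains a rough guess. In this assay the estimate for compound 3 is 300 nM with an expected range from 90 nM to 1000 nM around it.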

Compound 3, half-maximal inhibitory concentration: 110 nM
Compound 3: middle estimate off by 2.7-fold (0.44 log units), on the high side; the measured number falls inside the stated range.
By their numbers in this assay, from the lowest: compounds 3 and 1 (each within the scatter of the next); then compound 2.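

In this assay, placing a methyl on this aromatic carbon, ortho to an amino group and meta to a methyl group, gives a 1.6-fold lower number from compound 1 to compound 3 (0.21 log units; within the scatter) and so leaves compound 1 and compound 3 indistinguishable in this assay. Among the compounds shown here, this is the first single change that can be read directly here, as compound 1 and compound 2 differ in more than one place, and it shows that this position tolerates a methyl, with the hydrogen on this carbon not required for activity at the level of compound 1. No measurement at hand explains why the number stays within the scatter.

One methyl says little about how far this tolerance extends, so an ethyl, a methoxy group or a carboxylic acid on the same carbon could give quite a different number. On these data alone, it also remains open whether the same methyl would behave the same way on the core of compound 2, where the other substituents are different.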